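The source may hold more compounds than are shown below. What is called first, only, known or untested is meant among the compounds shown, and "the series" means these compounds.

The measured compounds:

- Compound 1, `Cc1cc(Cl)cc(-c2ccnc3cc(CN4C(=O)CCC4=O)sc23)c1O[C@H]1C[C@H](N)C1`, in an assay on RKO cells for inhibition of ubiquitin carboxyl-terminal hydrolase 7 (Homo sapiens), read by a luciferase reporter, with a stated time of 18 h (on this read-out lower numbers stand for an effect already at smaller amounts and higher numbers for an effect only at larger amounts of compound), gives 150 nM.
- Compound 2, `Cc1cc(Cl)cc(-c2ccnc3cc(CN4C(=O)C5CC5C4=O)sc23)c1C[C@@H]1CNC[C@@H](C)O1`, in this assay gives 60 nM.
- Compound 3, `Cc1cc(Cl)cc(-c2ccnc3cc(CN4C(=O)C5C(C4=O)C5(C)C)sc23)c1CC1CCCNC1`, in this assay gives 130 nM.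

Among these three numbers, compound 3 stands second highest. Its nearest neighbour is compound 1, whose number is only slightly higher, a gap that lies within the scatter of repeated measurements. Its furthest is compound 2, whose number is lower by a margin beyond that scatter. Within the data shown here, the three compounds differ from one another in more than one place, so no single step between them can be read from the numbers.

Compound 4, `Cc1cc(Cl)cc(-c2ccnc3cc(CN4C(=O)C5C(C4=O)C5(C)C)sc23)c1O[C@@H]1CCNC[C@@H]1C`, has not yet been measured. It differs from compound 3 in one place: (3-methylpiperidin-4-yl)oxy in place of (piperidin-3-yl)methyl on an aromatic carbon. Among the measured compounds shown here, since no change of this kind occurs between any two measured compounds, there is no step on which to lean. With the three numbers spanning only a modest range, a step of similar size in either direction would not be surprising, and none beyond the scatter is expected with confidence. Compound 4 is therefore expected to give about 130 nM in this assay, within a range from 45 nM to 380 nM. This estimate implies a step of no change at the digits printed from compound 3 to compound 4 (within the scatter).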

Compound 4, half-maximal effective concentration: 65 nM
Beside the measured number, compound 4's estimate is 2.0-fold (0.30 log units) above it, within the range that was stated.
By their numbers in this assay, from the lowest: compounds 2, 4, 3 and 1 (each within the scatter of the next, the first and the last beyond it).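

In this assay, (3-methylpiperidin-4-yl)oxy in place of (piperidin-3-yl)methyl gives a 2.0-fold lower number from compound 3 to compound 4 (0.30 log units; within the scatter). This is the only pair shown that differs in one place, and it gives the only direct reading of this position, on an aromatic carbon ortho to a methyl group and para to a chloro group: here, a larger group with an oxygen link, an added methyl group on the ring and 2 defined stereocentres is accepted with no shift beyond the scatter. No measurement shown explains this outcome.

From the compounds shown here alone, because these features enter together in a single step, the pair cannot separate their contributions, so the plain (piperidin-4-yl)oxy group and the other stereoisomers of the (3-methylpiperidin-4-yl)oxy group remain open questions. Also open, going by these compounds, is how the read-out at this position would respond to groups of a different kind, such as an open-chain aminoethoxy group or a carboxylic acid, and whether the same exchange would give a similar step on a different imide.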